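This account rests on a few compounds, and the source may have more. Where it says the series, first, only, none or still open, it means among the compounds named here.

Working notes on the series: in a functional assay on MCF7 cells (Homo sapiens) for cytotoxicity, read by MTT assay, with a stated time of 24 h (a higher number here means a weaker inhibitor, a lower number a stronger inhibitor), compound 1 `COc1cc2ncnc(Nc3cccc(C(F)(F)F)c3)c2cc1OCCCSc1nc2ccccc2s1` gives 4050 nM, the lowest of the three numbers so far. Compound 2 `COc1ccc(Nc2ncnc3cc(OC)c(OCCCSc4nc5ccccc5s4)cc23)cc1` gives 14200 nM and compound 3 `COc1cc2ncnc(Nc3ccc(C)cc3)c2cc1OCCCSc1nc2ccccc2s1` gives 14300 nM. Compound 4 `CCCCc1nc(Cl)c(CO)n1CCCOc1cc2c(Nc3cccc(C(F)(F)F)c3)ncnc2cc1OC` differs from compound 1 in one place: 2-butyl-4-chloro-5-(hydroxymethyl)-1H-imidazol-1-yl in place of (1,3-benzothiazol-2-yl)sulfanyl on a saturated chain carbon, three bonds along the chain from an oxygen on an aromatic ring. Within the data shown here, no measured step covers that place. The nearest guides are a 3.5-fold higher number from compound 1 to compound 2 (0.54 log units; beyond the scatter) and a 3.5-fold higher number from compound 1 to compound 3 (0.55 log units; beyond the scatter), both modest and both on a nitrogen on an aromatic ring, while a 1.0-fold higher number from compound 2 to compound 3 (0.00 log units; within the scatter) stays within the scatter. A change of similar or smaller size is therefore expected in this assay, leaning weakly towards a higher number. The expected step is a 1.4-fold higher number from compound 1 to compound 4 (0.13 log units; within the scatter), with its direction uncertain. Compound 4 is estimated at 5500 nM, with an expected range of 1500 nM to 20000 nM.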

Compound 4, half-maximal inhibitory concentration: 8280 nM
Compound 4: middle estimate off by 1.5-fold (0.18 log units), on the low side; the range from low to high includes it.
By their numbers in this assay, from the lowest: compound 1; then compounds 4, 2 and 3 (each within the scatter of the next).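

At the saturated chain carbon, three bonds along the chain from an oxygen on an aromatic ring, this assay shows a 2.0-fold higher number from compound 1 to compound 4 (0.31 log units; beyond the scatter) for 2-butyl-4-chloro-5-(hydroxymethyl)-1H-imidazol-1-yl in place of (1,3-benzothiazol-2-yl)sulfanyl. This place therefore moves the number too, and the step is modest although the six-membered aromatic ring leaves and a hydrogen-bond donor enters. Nothing available gives a reason for this step.

Which part of the entering group matters stays open: its butyl, chloro or hydroxymethyl. A morpholine or a carboxylic acid on this chain also remains unplaced.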